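This account rests on a few compounds, and the source may have more. Where it says the series, first, only, none or still open, it means among the compounds named here.

Of the compounds shown here, three of one series have been measured in a functional assay on MKN-45 cells (Homo sapiens) for cytotoxicity, read by MTT assay, with a stated time of 72 h; on this read-out lower numbers stand for stronger inhibition and higher numbers for weaker inhibition. Compound 1, `CCN(CC)CCCNc1nc(-c2ccc(NC(=O)Nc3ccc(F)cc3)cc2)nc2c(Cl)c(Cl)sc12`, gives 1700 nM in this assay. Compound 3, `CCN(CC)CCNc1nc(-c2ccc(NC(=O)Nc3ccc(F)cc3)cc2)nc2c(Cl)c(Cl)sc12`, gives 1370 nM in this assay. Compound 2, `CCN(CC)CCCNc1nc(-c2ccc(NC(=O)Nc3ccccc3F)cc2)nc2ccsc12`, gives 580 nM in this assay, the lowest of the three numbers; its gap to compound 3 and to compound 1 is in each case beyond the usual scatter. The difference between the core of compound 2 and the core of compound 1 is not broken down here.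

Compound 4, `CCN(CC)CCNc1nc(-c2ccc(NC(=O)Nc3ccccc3F)cc2)nc2ccsc12`, has not yet been measured in this assay. It differs from compound 2 by diethylamino in place of (diethylamino)methyl on a saturated chain carbon, two bonds along the chain from a nitrogen on an aromatic ring. The same change, at the same place, has already been made once in this series, from compound 1 to compound 3, where it gave a 1.2-fold lower number from compound 1 to compound 3 (0.09 log units; within the scatter). Since that step lay within the scatter, the change on its own has so far left the read-out essentially unmoved. Among the measured compounds shown here, compound 4 keeps the core of compound 2, and only this one change separates them.

On that basis compound 4 is expected to sit close to compound 2 in this assay, with an estimated step of a 1.2-fold lower number from compound 2 to compound 4 (0.06 log units; within the scatter), because the earlier step of a 1.2-fold lower number from compound 1 to compound 3 (0.09 log units; within the scatter) from compound 1 to compound 3 was small. The estimate for compound 4 is 500 nM, expected to fall between 250 nM and 1000 nM.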

Compound 4, half-maximal inhibitory concentration: 1040 nM
For compound 4 the middle estimate is 2.1-fold (0.32 log units) below the measured one, and the stated range ends below it.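

Measured in this assay, the exchange of (diethylamino)methyl for diethylamino gives a 1.8-fold higher number from compound 2 to compound 4 (0.25 log units; within the scatter). Set beside the earlier step, the change reads alike on the two cores, as far as this assay can tell: the same change on two cores in this assay, a 1.2-fold lower number (0.09 log units; within the scatter) from compound 1 to compound 3 and a 1.8-fold higher number (0.25 log units; within the scatter) from compound 2 to compound 4, 2.2-fold (0.35 log units) apart, within the scatter of two such steps This shows that on these two cores the exchange stays within the scatter and that the steps cannot be told apart, so the opposite directions of their numbers carry no weight; it does not show that the change would stay this small on any other core, and two pairs of compounds are a thin base for a rule about the series.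

The compounds shown carry only the 2-(diethylamino)ethyl and 3-(diethylamino)propyl chains, which leaves open how a longer chain, or a cyclic amine such as piperidine or morpholine in place of diethylamino, would read in this assay. Also open is how the chlorine atoms on the core of compound 1 and the different placing of fluorine on the terminal ring each bear on the read-out, as these two differences are never separated in the compounds shown.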